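The compounds below may be only part of what the source reports. "The series", "measured", "known", "first", "only" and "open" are said of these compounds alone.

Of the compounds shown here, three built on one shared core have been tested in a functional assay on HepG2 cells (Homo sapiens) for antiproliferative activity, read by MTT assay, with a stated time of 48 h; on this read-out higher numbers stand for weaker inhibition and lower numbers for stronger inhibition. Compound 1 `Cc1ccc(-c2nc3ccc(Cl)cc3c(=O)[nH]2)cc1` gives 9.86 ug/mL in this assay, and compound 2 `Cc1ccc(-c2nc3ccc(Cl)cc3c(=S)[nH]2)cc1` gives 7.01 ug/mL; these two numbers sit close together. Compound 3 `Cc1ccc(-c2nc(NO)c3cc(Cl)ccc3n2)cc1` gives 23.1 ug/mL, the highest of the three, so it is the weakest inhibitor in this small set: its nearest neighbour is compound 1, its gap to compound 2 is wider, and both gaps lie beyond the usual scatter.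

The step of interest leads from compound 3 to compound 4 `Cc1ccc(-c2nc(NC(=O)c3ccccc3)c3cc(Cl)ccc3n2)cc1`, which has not yet been measured. The change is benzoyl in place of hydroxy on a nitrogen on an aromatic ring, so that hydroxyamino becomes benzamido. Going by the values given here, no measured pair in this set shows what such a change does in this assay, so the direction of the step is open. The entering group brings many more heavy atoms than the one it replaces, and a modest move toward a lower number seems somewhat more likely than a move upward, though a step of no size beyond the scatter is also plausible. Compound 4 is therefore expected to come in at about 12 ug/mL, between 4 ug/mL and 40 ug/mL. This estimate corresponds to an expected step of a 1.9-fold lower number from compound 3 to compound 4 (0.28 log units; within the scatter), a guess rather than a measurement.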

Compound 4, half-maximal inhibitory concentration: 17.5 ug/mL
Compound 4: middle estimate off by 1.5-fold (0.16 log units), on the low side, within the range that was stated.
By their numbers in this assay, from the lowest: compounds 2, 1, 4 and 3 (each within the scatter of the next, the first and the last beyond it).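

In this assay, going by these compounds alone, benzoyl in place of hydroxy on a nitrogen on an aromatic ring gives a 1.3-fold lower number from compound 3 to compound 4 (0.12 log units; within the scatter), the first step in this set that can be read at this position. The entering benzoyl brings 8 heavy atoms and a six-membered aromatic ring where hydroxy had 1 heavy atom and no ring, and it has 0 hydrogen-bond donors where hydroxy had 1, yet the two numbers stay within the usual scatter of each other, so this single pair shows that a change this large in group size need not shift the read-out at this place. No measured property of these compounds is available that could explain this result.

Only hydroxy and benzoyl are shown on this nitrogen, so it remains open whether a plain amine, a small acetyl group or a longer chain such as hexanoyl would give a similar number. Going by these compounds, it is equally open whether a carboxylic acid or a methoxy group on the benzoyl ring would move the number, since a single step cannot show how far this tolerance extends.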